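This account rests on a few compounds, and the source may have more. Where it says the series, first, only, none or still open, it means among the compounds named here.

In a physicochemical assay for lipophilicity, read by HPLC, at pH 7.5 (on this read-out higher numbers stand for higher lipophilicity and lower numbers for lower lipophilicity), three compounds built on a shared core have been measured. Compound 1 `CC[C@@H](Nc1c(C#N)c(-c2ccc(-c3cccc(C)c3F)cc2)nc2cnccc12)C(N)=O` gives 3, compound 2 `CC[C@@H](Nc1c(C#N)c(-c2ccc(-c3cccnc3C)cc2)nc2cnccc12)C(N)=O` gives 1.9, and compound 3 `CC[C@@H](Nc1c(C#N)c(-c2ccc(-c3cccc(Cl)c3)cc2)nc2cnccc12)C(N)=O` gives 3.1. Compound 3 thus stands level with compound 1, with the step between them being a number 0.10 log units higher from compound 1 to compound 3 (within the scatter), and clear of compound 2, with a number 1.20 log units higher from compound 2 to compound 3 (beyond the scatter).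

The next compound, compound 4 `CC[C@@H](Nc1c(C#N)c(-c2ccc(-c3ccccc3Cl)cc2)nc2cnccc12)C(N)=O`, has not yet been measured. It differs from compound 3 only in the placing of the chlorine: 2-chlorophenyl in place of 3-chlorophenyl on an aromatic carbon. Here 2-chlorophenyl stands in place of 3-chlorophenyl, on an aromatic carbon para to a large group.

Among the compounds with values here, no measured step moves a chlorine around a ring, so the data offer no direct precedent. The two large steps, a number 1.10 log units lower from compound 1 to compound 2 (beyond the scatter) and the return to compound 3 already noted, both involve the 2-methylpyridin-3-yl group of compound 2, and the change at hand involves no such group. The closer guide is the exchange between two groups with rings of carbon only, from compound 1 to compound 3, which stayed within the scatter.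

A step beyond the scatter is therefore not expected in this assay, and the estimated step is a number 0.10 log units lower from compound 3 to compound 4 (within the scatter). For compound 4 the expected value is 3, within an estimated range from 2.6 to 3.4.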

Compound 4, distribution coefficient: 2.9
For compound 4 the middle estimate is 0.10 log units above the measured one, within the range that was stated.
By their numbers in this assay, from the lowest: compound 2; then compounds 4, 1 and 3 (each within the scatter of the next).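

Moving the chlorine is the first change here that leaves the atoms of the group as they were and alters only how they are joined: on an aromatic carbon para to a large group, this assay shows a number 0.20 log units lower from compound 3 to compound 4 (within the scatter) and so, for this pair, the placing of the chlorine on the ring does not carry the read-out beyond the scatter. Compound 4 also falls in with the other group with a ring of carbon only, at a number 0.10 log units lower from compound 1 to compound 4 (within the scatter) and still clear of the 2-methylpyridin-3-yl group, at a number 1.00 log units higher from compound 2 to compound 4 (beyond the scatter) and so compound 2 now stands apart from three compounds, not two. Nothing measured and shown here gives a reason for this closeness or for this gap.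

The compounds shown leave open how the read-out would stand with an amine or a carboxylic acid on this ring in place of the chlorine. They also leave open whether a plain pyridin-3-yl group, without the methyl, would sit as far from the other compounds as the 2-methylpyridin-3-yl group of compound 2 does.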